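Swapping an amide for fluorine on the shared core

The compounds below may be only part of what the source reports. "The series", "measured", "known", "first", "only" and "open" are said of these compounds alone.

Measured compounds in an assay (Rattus norvegicus) for inhibition of Fatty-acid amide hydrolase 1 (Homo sapiens); on this read-out lower numbers stand for stronger inhibition and higher numbers for weaker inhibition:
compound 1, `O=C(CCCCCCc1ccccc1)c1ncc(-c2cccc(O)c2)o1`, 50 nM
compound 2, `NC(=O)c1ccc(-c2cnc(C(=O)CCCCCCc3ccccc3)o2)cc1`, 10 nM
compound 3, `CNC(=O)c1cnc(C(=O)CCCCCCc2ccccc2)o1`, 7 nM

Compound 3 has the lowest number of the three. Its step from compound 2 is within the scatter, so the two cannot be ranked against each other, while the step from compound 1 is beyond the scatter: a 7.1-fold lower number from compound 1 to compound 3 (0.85 log units; beyond the scatter). Compound 2 likewise sits beyond the scatter from compound 1: a 5.0-fold lower number from compound 1 to compound 2 (0.70 log units; beyond the scatter). Between compound 2 and compound 3 the change is a 1.4-fold lower number from compound 2 to compound 3 (0.15 log units; within the scatter).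

Compound 4, `O=C(CCCCCCc1ccccc1)c1ncc(F)o1`, is not yet measured. It differs from compound 3 in this way: fluoro in place of methylcarbamoyl on an aromatic carbon.

Among the measured compounds shown here, no measured step exchanges a group for a single fluorine, so none bears on this change directly. The steps from compound 1 to compound 2 and from compound 1 to compound 3 show that the group on this aromatic carbon moves the number by modest amounts in either direction. Because compound 3 gives 7 nM with its methylcarbamoyl group, and the fluoro group carries none of what that group brings, a higher number is expected for compound 4, with a step of a 43-fold higher number from compound 3 to compound 4 (1.63 log units; beyond the scatter) expected. The estimate for compound 4 in this assay is 300 nM, within a range from 50 nM to 2000 nM.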

Compound 4, inhibition constant: 30 nM
Beside the measured number, compound 4's estimate is 10-fold (1.00 log units) above it; the measured number lies below the stated range.
By their numbers in this assay, from the lowest: compounds 3 and 2 (each within the scatter of the next); then compounds 4 and 1 (each within the scatter of the next).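

In this assay, a lone fluorine on this aromatic carbon, next to the ring oxygen, gives up the whole methylcarbamoyl group, including its hydrogen-bond donor and acceptor, yet the change is only a modest 4.3-fold higher number from compound 3 to compound 4 (0.63 log units; beyond the scatter) and lies beyond the scatter. Set against the larger aryl groups, fluoro gives a 3.0-fold higher number from compound 2 to compound 4 (0.48 log units; beyond the scatter), also beyond the scatter, and a 1.7-fold lower number from compound 1 to compound 4 (0.22 log units; within the scatter), which is within the scatter, so fluoro and 3-hydroxyphenyl cannot be ranked against each other. Among these four compounds, the two groups carrying an amide sit at lower numbers than the two without one, with no exception, and the smallest group here still matches a whole hydroxyphenyl ring, but no measurement accompanies these numbers that could explain the steps.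

On these data alone, what remains open is whether the amide itself matters or whether other groups at this position would do as well. A nitrile, a methyl ester, a carboxylic acid or a plain hydrogen on this carbon would test that, and chlorine would show whether fluorine's result is specific to fluorine.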